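The source may report more compounds than this note shows. Statements on the series, on what has been measured and on what is new or still open speak of the compounds shown alone.

Working notes on the shared core. In a functional assay on SW-620 cells (Homo sapiens) for inhibition, read by sulforhodamine B assay, with a stated time of 48 h (a lower number here means that less compound is tolerated, a higher number that more compound is tolerated), compound 1 `Nc1cc(N)c2nc(-c3ccccc3)c(Oc3ccc(Cl)c(Cl)c3)nc2c1` gives 91200 nM. For compound 2 `Nc1cc(N)c2nc(-c3ccccc3)c(NCc3ccc(Cl)c(Cl)c3)nc2c1` this assay reports only a limit, < 100000 nM. For compound 3 `CCOC(=O)[C@H](CCC(=O)O)NC(=O)c1ccc(Sc2nc3cc(N)cc(N)c3nc2-c2ccccc2)cc1` this assay likewise returns only a limit, < 100000 nM. The picture is thus dominated by the limit of < 100000 nM in this assay, at which 2 of the 3 values shown sit. Among the compounds with values here, no step between measured compounds can be read: compound 2 and compound 3 stand at the same limit, and compound 1 differs from both in more than one place. Compound 4 `COc1ccc(CNc2nc3cc(N)cc(N)c3nc2-c2ccccc2)cc1` is compound 2 with 4-methoxyphenyl in place of 3,4-dichlorophenyl on a saturated chain carbon bound to a nitrogen on an aromatic ring. Starting from a limit, no direction can be set; the expectation is a step that stays within the scatter, with compound 4 likely to remain near the limit. Compound 4 is estimated at 80000 nM, with a range from 20000 nM to 200000 nM. The expected step is a step that the limit leaves unreadable from compound 2 to compound 4.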

Compound 4, concentration lethal to 50% of the cells: 70800 nM
Beside the measured number, compound 4's estimate is 1.1-fold (0.05 log units) above it; the measured number falls inside the stated range.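

Compound 2 carries only a limit, so no step to compound 4 can be read: the limit of < 100000 nM in this assay, at which 2 of the 4 values shown sit.

Whether 4-methoxyphenyl in place of 3,4-dichlorophenyl changes the read-out in this assay at all stays open with the compounds shown.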